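A few compounds are considered here, and "the series" means these few. Any claim that something is new, unique, unknown or untested is made for them only; others in the source may bear on it.

Measured so far in a functional assay on the whole organism (strain Kunming) with Mus musculus as the target, in the maximal electroshock model, with a stated time of 4 h; a higher number here means that more compound is needed for the effect, a lower number that less compound is needed:

compound 1, `O=C1NC2(CC2c2ccc3cccc(OCc4ccccc4)c3n2)C(=O)N1c1ccc(C(F)(F)F)cc1`: 300 mg/kg
compound 2, `CC(C)N1C(=O)NC2(CC2c2ccc3cccc(OCc4ccccc4)c3n2)C1=O`: 100 mg/kg
compound 3, `O=C1NC2(CC2c2ccc3cccc(OCc4ccccc4)c3n2)C(=O)N1c1ccccc1`: 300 mg/kg

In this assay compound 3 stands level with compound 1, the two together giving the highest of the three numbers; no change at the digits printed from compound 1 to compound 3 (within the scatter). For the measured compounds named here, the one change that moves the number beyond the scatter is the swap of the aryl group on the ring nitrogen for an alkyl group: a 3.0-fold lower number from compound 1 to compound 2 (0.48 log units; beyond the scatter), and in the other direction a 3.0-fold higher number from compound 2 to compound 3 (0.48 log units; beyond the scatter).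

Compound 4, `O=C1NC2(CC2c2ccc3cccc(OCc4ccccc4)c3n2)C(=O)N1C1CCCCC1`, has not yet been measured. It differs from compound 3 in one place: cyclohexyl in place of phenyl on an amide-type nitrogen in a ring.

The step from compound 2 to compound 3 is the only one that bears on it, since it too exchanges phenyl on the ring nitrogen for a saturated carbon group. Whether a six-membered non-aromatic ring behaves like the isopropyl of compound 2 is not shown by any measured pair, so the expectation is a modest step toward a lower number, short of the full step seen between compound 3 and compound 2, and the expected step is a 2.0-fold lower number from compound 3 to compound 4 (0.30 log units; within the scatter). For compound 4 the estimate in this assay is 150 mg/kg, within a range from 70 mg/kg to 300 mg/kg.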

Compound 4, minimum effective dose: 300 mg/kg
Compound 4: middle estimate off by 2.0-fold (0.30 log units), on the low side; low and high end bracket the measured number.
By their numbers in this assay, from the lowest: compound 2; then compounds 1, 3 and 4 (each within the scatter of the next).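

In this assay, for the compounds shown here, the first reading at this position with a non-aromatic six-membered ring gives no change at the digits printed from compound 3 to compound 4 (within the scatter) for cyclohexyl in place of phenyl on the amide-type nitrogen in a ring, and no change at the digits printed from compound 1 to compound 4 (within the scatter) for cyclohexyl in place of 4-(trifluoromethyl)phenyl, so a split between aryl and alkyl groups no longer describes the series: cyclohexyl in compound 4 goes against it. Cyclohexyl in place of isopropyl gives a 3.0-fold higher number from compound 2 to compound 4 (0.48 log units; beyond the scatter) and thus separates two non-aromatic carbon groups at the same nitrogen, leaving compound 2 as the only one of the four set apart from the rest by a step beyond the scatter. No measurement shown gives a reason for this difference between isopropyl and cyclohexyl.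

The compounds shown leave open whether the lower number of compound 2 is particular to isopropyl or is shared by other open-chain or small-ring groups such as ethyl, tert-butyl or cyclopropyl. Also open, going by these compounds, is how the number responds to a group carrying heteroatoms on this nitrogen, such as an amine or a carboxylic acid at the end of a longer chain.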